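Bromo for Fluoro on the Benzyl Ring

This account rests on a few compounds, and the source may have more. Where it says the series, first, only, none or still open, it means among the compounds named here.

Measured compounds:
compound 1 `CC(=O)c1ccc(OCc2ccccc2F)cc1` — 47.1%
compound 2 `CC(=O)c1ccc(OCc2cccc(F)c2)cc1` — 48.4%
compound 3 `CC(=O)c1ccc(OCc2ccc(F)cc2F)cc1` — 45.7%

In an assay on isolated protein for inhibition of Amine oxidase [flavin-containing] A (Homo sapiens), read by Amplex Red, with a stated time of 15 min, tested at 100 uM (a higher number here means more inhibition at the concentration tested (going by the name of the read-out), a lower number less inhibition), compound 2 holds the largest of the three readings, yet its gaps to compound 1 and to compound 3 both fall within the usual scatter, so the three compounds cannot be told apart on these numbers. Compound 4 `CC(=O)c1ccc(OCc2cccc(Br)c2)cc1` differs from compound 2 by bromo in place of fluoro on an aromatic carbon. Within the data shown here, the only measured step, a number 1.4 percentage points lower from compound 1 to compound 3 (within the scatter), concerns fluoro in place of hydrogen and is itself within the scatter; no measured pair exchanges fluoro for bromo, so nothing here points to a shift in either direction. Compound 4 is therefore expected to stay close to compound 2, with a step of a number 1.6 percentage points higher from compound 2 to compound 4 (within the scatter). Compound 4 is estimated at 50%, in the range 35% to 65%.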

Compound 4, a percentage reported as inhibition, at one concentration (the size of the read-out at that concentration, not a potency): 48.3%
Beside the measured number, compound 4's estimate is 1.7 percentage points above it; measured number inside the range.
By their numbers in this assay, from the lowest: compounds 3, 1, 4 and 2 (each within the scatter of the next).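

In this assay, bromo in place of fluoro on the aromatic carbon meta to a large group gives a number 0.1 percentage points lower from compound 2 to compound 4 (within the scatter). Among these compounds, this is the first measured exchange of one halogen for another, and at this position it leaves the reading unchanged within the scatter. No measurement here offers an explanation for this result.

From the compounds shown here alone, all four compounds carry only halogen substituents on this ring, so it remains open whether an amine or a carboxylic acid at this position would move the reading. These single-concentration readings also leave potency undetermined.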